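The source may hold more compounds than are shown below. What is called first, only, known or untested is meant among the compounds shown, and "the series" means these compounds.

Compound 1 `COc1ccc(-c2nn(-c3ccccc3)cc2CNc2ccc(C)cc2)cc1`: 8160 nM
Compound 2 `Clc1ccc(NCc2cn(-c3ccccc3)nc2-c2ccc(Cl)cc2)cc1`: 2280 nM

In a functional assay on MCF7 cells (Homo sapiens) for antiproliferative activity, read by MTT assay, with a stated time of 48 h (a higher number here means a weaker inhibitor, a lower number a stronger inhibitor), compound 2 gives 2280 nM as the lower number of the two, and compound 1 gives 8160 nM. The gap between the two lies beyond the scatter, which makes compound 2 the stronger inhibitor so far. Compound 3 `COc1ccc(-c2nn(-c3ccccc3)cc2CNc2ccc(Cl)cc2)cc1` carries 4-methoxyphenyl where compound 2 carries 4-chlorophenyl, methoxy in place of chloro on an aromatic carbon. Compound 1, also a 4-methoxyphenyl compound, sits higher (8160 nM), which points to a rise. The expected step in this assay is modest, toward weaker inhibition and near the edge of the usual scatter (a 2.0-fold higher number from compound 2 to compound 3 (0.30 log units; within the scatter)). For compound 3 the estimated value is 4500 nM (range 1600 nM to 11000 nM).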

Compound 3, half-maximal inhibitory concentration: 6250 nM
For compound 3 the middle estimate is 1.4-fold (0.14 log units) below the measured one; the measured number falls inside the stated range.
By their numbers in this assay, from the lowest: compound 2; then compounds 3 and 1 (each within the scatter of the next).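

In this assay, within the data shown here, putting 4-methoxyphenyl in place of 4-chlorophenyl gives a 2.7-fold higher number from compound 2 to compound 3 (0.44 log units; beyond the scatter), the first reading of a single change at this position, and it shows that this swap alone separates the two compounds. Chloro in place of methyl, at the other place where the compounds differ, gives a 1.3-fold lower number from compound 1 to compound 3 (0.12 log units; within the scatter), so that change makes no clear difference here. Nothing measured on these compounds explains the result at the 4-chlorophenyl position. Open, as far as these compounds go, is how an amine or a carboxylic acid on that same aromatic carbon would compare with chloro and methoxy.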